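One added methoxy on compound 1

This account rests on a few compounds, and the source may have more. Where it says the series, first, only, none or still open, it means among the compounds named here.

Of the compounds shown here, two have numbers so far in a functional assay on the whole organism for inhibition, with Rattus norvegicus as the target; on this read-out lower numbers stand for stronger inhibition and higher numbers for weaker inhibition. Compound 1 `COc1ccccc1C1=NOC(=O)/C1=C\c1cccs1` gives 7100 nM, and compound 2 `O=C1ON=C(c2cccs2)/C1=C/c1ccccc1O` gives 5700 nM. These two values lie within the scatter of each other, so compound 1 cannot be ranked against compound 2 and the series has no measured spread yet.

Compound 3 `COc1ccc(OC)c(C2=NOC(=O)/C2=C\c2cccs2)c1` is still unmeasured. It differs from compound 1 by one change, methoxy in place of hydrogen on an aromatic carbon, meta to a large group and para to a methoxy group. For the measured compounds named here, no measured pair shows what such a change does, so no step beyond the scatter is expected in this assay, in either direction. The estimated step is a 1.2-fold lower number from compound 1 to compound 3 (0.07 log units; within the scatter). The estimated value for compound 3 is 6000 nM, with an expected range from 2000 nM to 18000 nM.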

Compound 3, half-maximal inhibitory concentration: 7900 nM
Compound 3: middle estimate off by 1.3-fold (0.12 log units), on the low side, and the stated range covers the measured number.
By their numbers in this assay, from the lowest: compounds 2, 1 and 3 (each within the scatter of the next).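

In this assay, methoxy in place of hydrogen on this aromatic carbon, meta to a large group and para to a methoxy group, gives a 1.1-fold higher number from compound 1 to compound 3 (0.05 log units; within the scatter). For the compounds shown here, this is the first measured pair for this change, and it shows that adding a methoxy group at this position produces no step beyond the scatter in this single case. No supporting measurement bears on the result.

With only methoxy shown at this position, it remains open whether a smaller or differently built group, such as an amine, a carboxylic acid or a longer alkoxy chain, would produce a step beyond the scatter. The same question stands for the other carbons of this ring, and no structural change has yet been tied to a step that can be read.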